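The source may report more compounds than this note shows. Statements on the series, on what has been measured and on what is new or still open speak of the compounds shown alone.

In a physicochemical assay for acid dissociation, compound 1 `COc1ccc(Oc2ccc3c(NCCCNCc4cccc(OC)c4O)ccnc3c2)cc1` gives 9.28, and compound 2 `COc1cccc(CNCCCNc2ccnc3cc(Oc4cccc(N(C)C)c4)ccc23)c1O` gives 9.28. Compound 3 `CCC(CC)c1ccc2c(NCCCNCc3cccc(OC)c3O)ccnc2c1` gives 9.47, the highest of the three numbers, though its steps to the others, a number 0.19 log units higher from compound 1 to compound 3 (within the scatter) and a number 0.19 log units higher from compound 2 to compound 3 (within the scatter), both lie within the scatter. Compound 4 `COc1cccc(CNCCCNc2ccnc3cc(-c4cccc5ccccc45)ccc23)c1O` is not yet measured. The change naphthalen-1-yl in place of pentan-3-yl on an aromatic carbon sits on the same aromatic carbon as those two steps, which exchanged a ring-bearing oxygen for a chain with no shift beyond the scatter. Accordingly, compound 4 is expected to show no step beyond the scatter, with a number 0.07 log units lower from compound 3 to compound 4 (within the scatter) as the estimated move. The estimate for compound 4 in this assay is 9.4, within 9 to 9.8.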

Compound 4, acid dissociation constant: 9.47
Compound 4: the middle estimate sits 0.07 log units below what was measured, and the stated range covers the measured number.
By their numbers in this assay, from the lowest: compounds 1, 2, 3 and 4 (each within the scatter of the next).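

In this assay, putting naphthalen-1-yl in place of pentan-3-yl on this aromatic carbon gives no change at the digits printed from compound 3 to compound 4 (within the scatter), while putting it in place of the two aryl ether groups gives a number 0.19 log units higher from compound 2 to compound 4 (within the scatter) and a number 0.19 log units higher from compound 1 to compound 4 (within the scatter). For the compounds shown here, a group of two six-membered aromatic rings of carbon only thus joins a chain with no ring and two ring-bearing oxygen groups at this place, and no step among the four compounds lies beyond the scatter. Nothing is available that would explain these numbers. The compounds shown leave open whether a carboxylic acid or a primary amine on this aromatic carbon would also stay within the scatter.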